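Bromo Traded for Cyano on the Isopropoxy Ring

The compounds below may be only part of what the source reports. "The series", "measured", "known", "first", "only" and "open" are said of these compounds alone.

Among the measured compounds shown here, in a functional assay on CHO cells for agonist activity at sphingosine 1-phosphate receptor 5 (Homo sapiens), read by GTPgammaS binding (on this read-out higher numbers stand for an effect only at larger amounts of compound and lower numbers for an effect already at smaller amounts), compound 2 `Cc1cc(CCC(=O)O)ccc1-c1noc(-c2ccc(OC(C)C)c(Br)c2)n1` gives 43 nM, the lowest of the two numbers measured so far; compound 1 `Cc1cc(-c2nc(-c3ccc(CCC(=O)O)cc3C)no2)ccc1OC(C)C` gives 210 nM in this assay. For the measured compounds named here, the only measured step, a 4.9-fold lower number from compound 1 to compound 2 (0.69 log units; beyond the scatter), concerned bromo replacing methyl, so it does not directly cover the present change. Compound 3 `Cc1cc(CCC(=O)O)ccc1-c1noc(-c2ccc(OC(C)C)c(C#N)c2)n1` differs from compound 2 by cyano in place of bromo on an aromatic carbon. Nothing measured tests this exact swap. The change is expected to be a 1.6-fold higher number from compound 2 to compound 3 (0.21 log units; within the scatter), a small shift that may fall within the scatter. Compound 3 is therefore expected to give about 70 nM, estimated within a range from 25 nM to 250 nM.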

Compound 3, half-maximal effective concentration: 6.5 nM
Beside the measured number, compound 3's estimate is 11-fold (1.03 log units) above it; measured number below the stated range.
By their numbers in this assay, from the lowest: compound 3; then compound 2; then compound 1.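

At this position the choice of group matters more than the earlier step showed: in this assay, cyano in place of bromo gives a 6.6-fold lower number from compound 2 to compound 3 (0.82 log units; beyond the scatter) and so outdoes the gain bromo made over methyl. Cyano in place of methyl adds up to a 32-fold lower number from compound 1 to compound 3 (1.51 log units; beyond the scatter) for this single place on the ring. Nothing available explains why cyano does so well here.

Still open, as far as these compounds go, is whether a trifluoromethyl, a methoxy or an amide at this place would give a lower number still. From the compounds shown here alone, whether the cyano gain would hold with a group other than the isopropoxy group also remains open.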